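The compounds below may be only part of what the source reports. "The series", "measured", "known", "first", "only" and "open" are said of these compounds alone.

Working notes: in a functional assay on the whole organism for antagonist activity, with Mus musculus as the target (a higher number here means that more compound is needed for the effect, a lower number that less compound is needed), compound 1 `CC(C)NCC(=O)NCC(=O)N(C)c1ccc(Cl)cc1C(=O)c1ccccc1Cl` gives 1 mg/kg, compound 2 `CCC(=O)NCC(=O)N(C)c1ccc(Cl)cc1C(=O)c1ccccc1Cl` gives 1.4 mg/kg and compound 3 `CCCCCCC(=O)NCC(=O)N(C)c1ccc(Cl)cc1C(=O)c1ccccc1Cl` gives 1.9 mg/kg. Compound 3 lies within the scatter of both others, and its nearest neighbour on the numbers is compound 2 (a 1.4-fold higher number from compound 2 to compound 3 (0.13 log units; within the scatter)). Compound 4 `CN(C)CC(=O)NCC(=O)N(C)c1ccc(Cl)cc1C(=O)c1ccccc1Cl` differs from compound 3 by dimethylamino in place of pentyl on a saturated chain carbon bound to a carbonyl carbon. The closest measured changes replace isopropylamino at that place: pentyl gives a 1.9-fold higher number from compound 1 to compound 3 (0.28 log units; within the scatter) and methyl gives a 1.4-fold higher number from compound 1 to compound 2 (0.15 log units; within the scatter). Both lie within the scatter, so no step beyond it is expected in this assay. The expected step is a 1.6-fold lower number from compound 3 to compound 4 (0.20 log units; within the scatter). Compound 4 is estimated at 1.2 mg/kg, with an expected range of 0.6 mg/kg to 2.8 mg/kg.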

Compound 4, dose for half-maximal effect: 2.6 mg/kg
For compound 4 the middle estimate is 2.2-fold (0.34 log units) below the measured one; measured number inside the range.
By their numbers in this assay, from the lowest: compounds 1, 2, 3 and 4 (each within the scatter of the next, the first and the last beyond it).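

In this assay the saturated chain carbon bound to a carbonyl carbon now shows its first step beyond the scatter (a 2.6-fold higher number from compound 1 to compound 4 (0.41 log units; beyond the scatter)), a modest one between two amino groups. Dimethylamino nevertheless stays within the scatter of both groups without nitrogen, pentyl (a 1.4-fold higher number from compound 3 to compound 4 (0.14 log units; within the scatter)) and methyl (a 1.9-fold higher number from compound 2 to compound 4 (0.27 log units; within the scatter)), so the presence of an amino group alone does not separate the compounds here. No supporting measurement bears on this result.

Open, from the compounds shown here alone, is how an unsubstituted amine, diethylamino or a carboxylic acid at this place would read in this assay. Also open, going by these compounds, is whether the step between the two amino groups holds on a different core.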